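Bicyclic acyl group in place of difluorocyclohexyl on compound 2

The compounds below may be only part of what the source reports. "The series", "measured", "known", "first", "only" and "open" are said of these compounds alone.

Compound 1 `O=C(c1ccc(F)c(F)c1)N1CC(c2nc(-c3cccc(F)c3)no2)C1`: 3200 nM
Compound 2 `O=C(C1CCC(F)(F)CC1)N1CC(c2nc(-c3cccc(Cl)c3)no2)C1`: 180 nM
Compound 3 `Cc1cccc(-c2noc(C3CN(C(=O)C4CCC(F)(F)CC4)C3)n2)c1`: 590 nM

Of the compounds shown here, three sharing the same core have been measured in an assay on HEK293 cells for positive allosteric modulation of metabotropic glutamate receptor 5 (Homo sapiens), read by FLIPR; a lower number here means that less compound is needed, a higher number that more compound is needed for the effect. Compound 2 stands lowest of the three numbers; its nearest neighbour is compound 3, which shows a 3.3-fold higher number from compound 2 to compound 3 (0.52 log units; beyond the scatter), and the furthest is compound 1, whose value is higher still. Compound 1 differs from compound 2 in two places at once, so its gap to compound 2 cannot be assigned to either change alone.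

Compound 4 `O=C([C@@H]1CC2CCC1C2)N1CC(c2nc(-c3cccc(Cl)c3)no2)C1` has not yet been measured. It differs from compound 2 by a group of 7 heavy atoms (7 carbon; 2 five-membered non-aromatic rings of carbon only) in place of a group of 8 heavy atoms (6 carbon, 2 fluorine; one six-membered non-aromatic ring of carbon only), on a carbonyl carbon. Among the compounds with values here, no measured step touches the acyl group on this carbonyl carbon: the only single-point step available, from compound 2 to compound 3, concerns the aromatic chloro and says nothing about the acyl side. Because the step of a 3.3-fold higher number from compound 2 to compound 3 (0.52 log units; beyond the scatter) lies on a different part of the molecule, no direction can be taken from it, and the expectation for compound 4 rests on the value of compound 2 alone, with a wide range.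

For compound 4 the estimate in this assay is 300 nM, between 100 nM and 1200 nM, which would mean an expected 1.7-fold higher number from compound 2 to compound 4 (0.22 log units; within the scatter).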

Compound 4, half-maximal effective concentration: 98 nM
Estimate against measurement, compound 4: 3.1-fold (0.49 log units) above; the whole stated range lies above it.
By their numbers in this assay, from the lowest: compounds 4 and 2 (each within the scatter of the next); then compound 3; then compound 1.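

In this assay, the acyl group on the carbonyl carbon now has its first single-point step: with the 3-chlorophenyl side of compound 2 left as it is, putting the group with 2 five-membered non-aromatic rings of carbon only in place of 4,4-difluorocyclohexyl gives a 1.8-fold lower number from compound 2 to compound 4 (0.26 log units; within the scatter). The number therefore does not separate these two groups, so at this position the fluorine-bearing six-membered ring can be exchanged for this all-carbon group with no change beyond the scatter, although this single exchange alters the ring and removes the fluorine atoms together and cannot divide the two. No measurement available here bears on why the two groups read alike.

The compounds shown leave open whether the defined stereocentre of the entering group matters, and how a plain cyclohexyl, a tert-butyl or a ring carrying an amine would read on this carbonyl carbon. Compound 1 carries an aromatic acyl group but differs from compound 2 and compound 4 in more than one place, so its steps to them cannot be read.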